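The source may hold more compounds than are shown below. What is called first, only, known or untested is meant among the compounds shown, and "the series" means these compounds.

In an ADME assay on Vero cells (Chlorocebus sabaeus) for cytotoxicity, read by MTT assay, with a stated time of 48 h (on this read-out lower numbers stand for stronger inhibition and higher numbers for weaker inhibition), compound 1 `O=C(OC1CCC(CN2CCN(c3cc(=O)c4cc(C(F)(F)F)cc([N+](=O)[O-])c4s3)CC2)CC1)c1ccccc1` gives > 64 ug/mL as a limit of the assay. Compound 2 `O=c1cc(N2CCN(CC3CCC(OS(=O)(=O)c4cccnc4)CC3)CC2)sc2c([N+](=O)[O-])cc(C(F)(F)F)cc12` gives > 64 ug/mL as a limit too. Compound 3 `CCCC(=O)OC1CCC(CN2CCN(c3cc(=O)c4cc(C(F)(F)F)cc([N+](=O)[O-])c4s3)CC2)CC1` gives > 64 ug/mL as a limit as well, so no number places it.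

Compound 4 `CS(=O)(=O)NC1CCC(CN2CCN(c3cc(=O)c4cc(C(F)(F)F)cc([N+](=O)[O-])c4s3)CC2)CC1` carries methanesulfonamido in place of (propylcarbonyl)oxy on a saturated ring carbon. Within the data shown here, three measured steps bear on this change: a step that the two limits leave unreadable from compound 1 to compound 2, a step that the two limits leave unreadable from compound 1 to compound 3 and a step that the two limits leave unreadable from compound 2 to compound 3. None of them has a readable size.

Given (the limit of > 64 ug/mL in this assay, at which 3 of the 3 values shown sit), which includes compound 3, no step beyond the scatter is expected in this assay. The estimated change is a number no higher from compound 3 to compound 4 (the limit leaves the size open). For compound 4 the estimate is 64 ug/mL, with an expected range from 32 ug/mL to 128 ug/mL.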

Compound 4, half-maximal inhibitory concentration: 48.5 ug/mL
The estimate for compound 4 lay 1.3-fold (0.12 log units) above the measured number; the range from low to high includes it.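

Among compound 1, compound 2 and compound 3 no step can be read, whereas in this assay compound 4, with methanesulfonamido on the saturated ring carbon, gives 48.5 ug/mL, a number and not a limit. Methanesulfonamido in place of the three oxygen-linked groups gives an at least 1.3-fold lower number from compound 3 to compound 4 (0.12 log units; that floor lies within the scatter), an at least 1.3-fold lower number from compound 2 to compound 4 (0.12 log units; that floor lies within the scatter) and an at least 1.3-fold lower number from compound 1 to compound 4 (0.12 log units; that floor lies within the scatter). Each size is only a floor, because the other end of each step is a limit: the limit of > 64 ug/mL in this assay, at which 3 of the 4 values shown sit.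

Going by these compounds, the true size of these steps stays open. So does the value that an amine or a carboxylic acid on the same saturated ring carbon would give in this assay.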